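A Methyl Step on a Cyano Nucleoside Core

The source may report more compounds than this note shows. Statements on the series, on what has been measured and on what is new or still open speak of the compounds shown alone.

Compound 1, with the structure `N#C[C@]1(O)[C@H](O)[C@@H](CO)O[C@@H](n2ccc(O)nc2=O)[C@@H]1O`, was tested in a functional assay on L1210 cells (Mus musculus) (on this read-out higher numbers stand for weaker inhibition and lower numbers for stronger inhibition), where compound 1 gives 417000 nM. Compound 2, with the structure `Cc1cn([C@@H]2O[C@H](CO)[C@@H](O)[C@@](O)(C#N)[C@H]2O)c(=O)nc1O`, carries the change (methyl in place of hydrogen on an aromatic carbon). In this assay compound 2 gives 539000 nM, so the step is a 1.3-fold higher number from compound 1 to compound 2 (0.11 log units; within the scatter), a change that does not move the read-out in any way the assay can tell apart from noise.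

Compound 3, with the structure `N#C[C@H]1[C@@H](O)[C@H](n2ccc(O)nc2=O)O[C@H](CO)[C@H]1O`, rests on a related but distinct core; how the core of compound 3 differs from the core of compound 1 is not broken down here. In this assay compound 3 gives > 500000 nM, which is a limit of the assay rather than a number, as stated in the limit of > 500000 nM in this assay, at which 1 of the 3 values shown sits.

Compound 4, with the structure `Cc1cn([C@@H]2O[C@H](CO)[C@@H](O)[C@@H](C#N)[C@H]2O)c(=O)nc1O`, has not yet been measured. Within the data shown here, it carries the change (methyl in place of hydrogen on an aromatic carbon), the same change, made on the same kind of place, as the one that separates compound 1 from compound 2. The step from compound 3 to compound 4 is therefore expected to be small, about a step that the limit leaves unreadable from compound 3 to compound 4, because a 1.3-fold higher number from compound 1 to compound 2 (0.11 log units; within the scatter) showed the same change staying within the scatter. On that basis compound 4 is estimated at 650000 nM, with a range from 350000 nM to 1300000 nM, and it is likely that the assay again reports only a limit for compound 4.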

Compound 4, half-maximal inhibitory concentration: > 750000 nM
Compound 4: only a limit was reported; the forecaster's own chance of this, stated with the estimate: 70%; middle value at least 1.1-fold (0.06 log units) from the limit.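

In this assay compound 3 and compound 4 each give only a limit and not a number, so no step can be read between them. The compounds shown leave open whether methyl in place of hydrogen on an aromatic carbon changes the read-out on the core of compound 3 as little as it does on the core of compound 1.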